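The source may report more compounds than this note shows. Statements on the series, on what has been measured and on what is new or still open speak of the compounds shown alone.

Of the compounds shown here, three have been measured in a functional assay, tested at 100 ug/mL; a lower number here means a stronger effect, a higher number a weaker effect of the compound at the concentration tested. Compound 1 `CCOC(=O)C1=C(C)N(c2ccc(C)cc2)C=CC1c1ccccc1` gives -22.9%, compound 2 `CCOC(=O)C1=C(C)N(c2ccccc2)C=CC1c1ccccc1[N+](=O)[O-]` gives -20.6%, and compound 3 `COC(=O)C1=C(C)N(c2ccc(OC)cc2)C=C(C)C1c1ccccc1` gives -19.8%. Compound 3 carries the highest of the three numbers, but its nearest neighbour, compound 2, and its furthest, compound 1, both lie within the scatter, so the three cannot be set in order. Compound 4 `COC(=O)C1=C(C)N(c2cccc(C)c2C)C=C(C)C1c1ccccc1` is the next compound to be tested: 2,3-dimethylphenyl in place of 4-methoxyphenyl on an amine nitrogen in a ring. Within the data shown here, no pair of measured compounds differs in one place only, so nothing shows how such a change moves the read-out in this assay; the expected step is a number 0.8 percentage points higher from compound 3 to compound 4 (within the scatter), within the scatter and in no particular direction. Compound 4 is expected to give about -19% in this assay, with a range from -31% to -7%.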

Compound 4, a percentage reported as activity, at one concentration (the size of the read-out at that concentration, not a potency): -23.6%
Compound 4: the middle estimate sits 4.6 percentage points above what was measured; the range from low to high includes it.
By their numbers in this assay, from the lowest: compounds 4, 1, 2 and 3 (each within the scatter of the next).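

In this assay, among these compounds, 2,3-dimethylphenyl in place of 4-methoxyphenyl on the amine nitrogen in the ring gives the first step that can be read at a single place: a number 3.8 percentage points lower from compound 3 to compound 4 (within the scatter). Exchanging these two substituted phenyl groups at this position, including the loss of the methoxy oxygen, therefore gives no difference that can be claimed. Nothing at hand bears on the reason for this result.

Still open, from the compounds shown here alone, is whether a benzyl group or a longer alkyl chain on this nitrogen would give a step beyond the scatter. A carboxylic acid on the phenyl group there is equally untested by the compounds shown.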